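Selenocyanate carbamates: from an isopropyl chain to a phenyl

The compounds below may be only part of what the source reports. "The series", "measured", "known", "first", "only" and "open" are said of these compounds alone.

compound 1, `CC(C)COC(=O)Nc1ccc([Se]C#N)cc1`: 8100 nM
compound 2, `O=C(Nc1ccc([Se][Se]c2ccc(NC(=O)Oc3ccc(F)cc3)cc2)cc1)Oc1ccc(F)cc1`: 18500 nM
compound 3, `N#C[Se]c1ccc(NC(=O)Oc2ccc(Cl)cc2)cc1`: 11800 nM

Of the compounds shown here, three have been tested in a functional assay on HT-29 cells (Homo sapiens) for cytotoxicity, read by MTT assay, with a stated time of 72 h; a lower number here means a stronger inhibitor of growth, a higher number a weaker inhibitor of growth. Compound 1 gives 8100 nM, the lowest number of the three. Compound 3 lies nearest, with a number that is somewhat higher but within the usual scatter, so the two cannot be told apart. Compound 2 stands furthest away, with a number beyond the scatter, so compound 2 is the weaker growth inhibitor of that pair. Among the measured compounds shown here, with only three numbers and no pair differing in a single place, no step between measured compounds can be drawn.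

Compound 4, `N#C[Se]c1ccc(NC(=O)OCc2ccccc2)cc1`, is not yet measured in this assay. It differs from compound 1 in one place: phenyl in place of isopropyl on a saturated chain carbon bound to an oxygen next to a carbonyl group. The rest of compound 1 is kept. For the measured compounds named here, nothing among the measured compounds shows the effect of such a change on this core, so the direction is open; the expectation is a step of modest size, most likely none beyond the scatter. Compound 4 is therefore expected to give about 7000 nM, within a range from 2500 nM to 20000 nM, which means an estimated step of a 1.2-fold lower number from compound 1 to compound 4 (0.06 log units; within the scatter).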

Compound 4, concentration for 50% growth inhibition: 13300 nM
Compound 4: the middle estimate sits 1.9-fold (0.28 log units) below what was measured; the range from low to high includes it.
By their numbers in this assay, from the lowest: compounds 1, 3, 4 and 2 (each within the scatter of the next, the first and the last beyond it).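

In this assay, among the compounds shown here, phenyl in place of isopropyl on a saturated chain carbon bound to an oxygen next to a carbonyl group gives a 1.6-fold higher number from compound 1 to compound 4 (0.22 log units; within the scatter), the first step that can be read at this position. This single step shows that, on the core of compound 1, the number stays within the usual scatter when the isopropyl, with its 3 heavy atoms and no ring, gives way to a phenyl, with its 6 heavy atoms and one six-membered aromatic ring of carbon only, so compound 1 and compound 4 cannot be told apart in this assay. No measurement shown here offers an explanation for this result.

The compounds shown leave open whether a group of another kind at this place, such as an amine, a carboxylic acid or a longer chain, would produce a step beyond the scatter. They also leave open whether the result from this one pair would hold for a phenyl in place of isopropyl on any other core, since it rests on compound 1 and compound 4 alone.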